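A Phosphorus Group on the Aromatic Oxygen of Compound 1

The compounds below may be only part of what the source reports. "The series", "measured", "known", "first", "only" and "open" are said of these compounds alone.

Compound 1 `COc1cc(/C=C\Cc2cc(O)c3ccsc3c2)cc(OC)c1OC` gives 49 nM
Compound 2 `COc1cc(/C=C\Cc2cc(O)c3ccoc3c2)cc(OC)c1OC` gives 31 nM

Both numbers come from a functional assay on HUVEC cells (Homo sapiens) for antiproliferative activity (a lower number here means a stronger inhibitor, a higher number a weaker inhibitor), and lie within the usual scatter of each other, so compound 1 cannot be separated from compound 2 on this evidence. Compound 3 `COc1cc(/C=C\Cc2cc(OP(=O)(O)O)c3ccsc3c2)cc(OC)c1OC` keeps the core of compound 1 and carries a group of 4 heavy atoms (3 oxygen, 1 phosphorus; no ring) in place of a hydrogen atom, on an oxygen on an aromatic ring on an oxygen on an aromatic ring. Going by the values given here, no measured pair shows such a change, so in this assay only a small step toward a higher number, a weaker inhibitor, is expected, perhaps none beyond the scatter. The expected step is a 1.4-fold higher number from compound 1 to compound 3 (0.15 log units; within the scatter) on this estimate. Compound 3 is estimated at 70 nM (expected range 20 nM to 250 nM).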

Compound 3, half-maximal inhibitory concentration: 83 nM
Beside the measured number, compound 3's estimate is 1.2-fold (0.07 log units) below it; measured number inside the range.
By their numbers in this assay, from the lowest: compounds 2, 1 and 3 (each within the scatter of the next, the first and the last beyond it).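

In this assay the group of 4 heavy atoms (3 oxygen, 1 phosphorus) can stand in place of a hydrogen atom on this oxygen on an aromatic ring without a clear loss: the step of a 1.7-fold higher number from compound 1 to compound 3 (0.23 log units; within the scatter) leaves compound 3 inseparable from compound 1. Going by these compounds alone, the earlier compounds carried no change at this oxygen, so this is the first reading of one. No measurement shown here accounts for the result.

Going by these compounds, a methyl or an acetyl group on the same oxygen remains open, as does an amine in its place. Also open, on these data alone, is whether the phosphorus group would give a similar step on compound 2.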